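Chain extension in a benzisoxazole-free sulfonamide series: compound 3

The source may report more compounds than this note shows. Statements on the series, on what has been measured and on what is new or still open speak of the compounds shown alone.

Compound 1 `CNS(=O)(=O)Cc1noc2ccccc12` gives 23 mg/kg in a functional assay on the whole organism (strain STD-dd) with Mus musculus as the target, in the maximal electroshock model, with a stated time of 2 h; a higher number here means that more compound is needed for the effect, a lower number that less compound is needed. Compound 2 `NS(=O)(=O)CCc1noc2ccccc12` gives 26 mg/kg in this assay. The step of a 1.1-fold higher number from compound 1 to compound 2 (0.05 log units; within the scatter) is the only measured one, and it leaves compound 2 standing alongside compound 1, within the scatter, with no order between the two numbers to be read.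

Compound 3 `NS(=O)(=O)CCCc1noc2ccccc12` is not yet measured. Against compound 2 the change is sulfamoylmethyl in place of sulfamoyl on a saturated chain carbon, two bonds along the chain from an aromatic carbon. For the measured compounds named here, the one measured step that bears on it, a 1.1-fold higher number from compound 1 to compound 2 (0.05 log units; within the scatter), also inserted a chain carbon between the aromatic core and the sulfamoyl group, and moved the number by nothing beyond the scatter. On that basis no step beyond the scatter is expected from compound 2 to compound 3 in this assay; the expected step is a 1.2-fold higher number from compound 2 to compound 3 (0.06 log units; within the scatter). Compound 3 is estimated at 30 mg/kg, with a range from 14 mg/kg to 65 mg/kg, the range widened slightly because only a 1.1-fold higher number from compound 1 to compound 2 (0.05 log units; within the scatter) informs it.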

Compound 3, dose for half-maximal effect: 39 mg/kg
For compound 3 the middle estimate is 1.3-fold (0.11 log units) below the measured one; low and high end bracket the measured number.
By their numbers in this assay, from the lowest: compounds 1, 2 and 3 (each within the scatter of the next).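

In this assay the change to sulfamoylmethyl in place of sulfamoyl, on a saturated chain carbon, two bonds along the chain from an aromatic carbon, gives a 1.5-fold higher number from compound 2 to compound 3 (0.18 log units; within the scatter) and so stays within the scatter. Unlike the earlier step of a 1.1-fold higher number from compound 1 to compound 2 (0.05 log units; within the scatter), which also removed the methyl of methylsulfamoyl, this one changes the chain alone, with the unsubstituted sulfamoyl kept, and the chain change on its own shows no step beyond the scatter. Nothing available bears on the reason for this reading.

For the compounds shown here, with every step so far within the scatter, no dependence of the number on chain length can be read from these compounds. Open, as far as these compounds go, are a longer chain still carrying sulfamoyl, and a carboxylic acid or an amine in place of sulfamoyl on the same chain.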